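The source may hold more compounds than are shown below. What is called first, only, known or untested is meant among the compounds shown, and "the series" means these compounds.

Measured in a functional assay on Jurkat cells (Homo sapiens) for cytotoxicity, read by luminescence and CellTiter-Glo, with a stated time of 3 days; on this read-out lower numbers stand for stronger inhibition and higher numbers for weaker inhibition:
Compound 1 `N#Cc1ccc(NC(=O)c2ccc3cccnc3c2O)c(F)c1`: 420 nM
Compound 2 `Cc1cc(C#N)ccc1NC(=O)c1ccc2cccnc2c1O`: 270 nM
Compound 3 `N#Cc1ccc(NC(=O)c2ccc3cccnc3c2O)cc1`: 180 nM

Compound 3 cannot be told apart from compound 2, as the record shows a 1.5-fold lower number from compound 2 to compound 3 (0.18 log units; within the scatter). It does stand clear of compound 1, with a 2.3-fold lower number from compound 1 to compound 3 (0.37 log units; beyond the scatter).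

The next compound, compound 4 `O=C(Nc1ccc(C(F)(F)F)cc1)c1ccc2cccnc2c1O`, keeps the shared core and changes one group: trifluoromethyl in place of cyano on an aromatic carbon. In words, this is trifluoromethyl in place of cyano on an aromatic carbon, para to a large group.

Among the measured compounds shown here, no measured step touches the cyano group itself, so the evidence is indirect. The measured steps swap fluoro, methyl and hydrogen at another place, and they stay small: a 1.6-fold lower number from compound 1 to compound 2 (0.19 log units; within the scatter) and, the largest, a 2.3-fold lower number from compound 1 to compound 3 (0.37 log units; beyond the scatter). From the compounds shown here alone, those steps suggest that these compounds respond only mildly to a single small swap, though this one remains untested.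

No step beyond the scatter is therefore expected, and the estimate is a 1.1-fold higher number from compound 3 to compound 4 (0.05 log units; within the scatter). For compound 4 the expected value is 200 nM, with an estimated range from 80 nM to 500 nM.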

Compound 4, half-maximal inhibitory concentration: 550 nM
Compound 4: middle estimate off by 2.8-fold (0.44 log units), on the low side, and the stated range ends below it.
By their numbers in this assay, from the lowest: compounds 3, 2, 1 and 4 (each within the scatter of the next, the first and the last beyond it).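

Replacing cyano with trifluoromethyl, in this assay, gives a 3.1-fold higher number from compound 3 to compound 4 (0.49 log units; beyond the scatter). The earlier compounds shown here differed only at another place, so they could not show that this position, para to a large group, responds to a change beyond the scatter. Nothing measured here explains why trifluoromethyl gives the higher number, and no supporting data on either group are available.

With only cyano and trifluoromethyl compared at this position, there is no trend to follow, and an amine, a carboxylic acid or a longer chain there could give a number on either side of these two. From the compounds shown here alone, it also remains open whether the fluoro or methyl seen at the other place would change the number in the same way when trifluoromethyl replaces cyano.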